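Aryloxy swap on the shared core: permeability notes

The compounds below may be only part of what the source reports. "The series", "measured", "known", "first", "only" and "open" are said of these compounds alone.

Of the compounds shown here, two have numbers so far. Compound 1 `Cn1c(COc2cccc(C(=O)O)c2)nc2cnc(Oc3ccc(Cl)c(F)c3)cc21` gives 11.2 10^-6 cm/s in an ADME assay for permeability, using PAMPA, with a stated time of 4 h; a lower number here means that the compound crosses the layer more slowly, a higher number that the compound crosses the layer faster. Compound 2 `Cn1c(COc2cccc(C(=O)O)c2)nc2ccc(Oc3cccc(Cl)n3)cc21` gives 7.6 10^-6 cm/s in this assay, the lower of the two numbers, though its gap to compound 1 lies within the scatter. Compound 3 `Cc1ccc(Oc2ccc3nc(COc4cccc(C(=O)O)c4)n(C)c3c2)nc1C` is not yet measured; it differs from compound 2 by 5,6-dimethylpyridin-2-yl in place of 6-chloropyridin-2-yl on an oxygen on an aromatic ring. Within the data shown here, no step between measured compounds matches this change, so the expected step of a 1.1-fold higher number from compound 2 to compound 3 (0.02 log units; within the scatter) is small, with no direction beyond the scatter. Compound 3 is therefore estimated at 8 10^-6 cm/s, within 4 10^-6 cm/s to 16 10^-6 cm/s.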

Compound 3, apparent permeability: 7.7 10^-6 cm/s
Compound 3: middle estimate off by 1.0-fold (0.02 log units), on the high side; the range from low to high includes it.
By their numbers in this assay, from the lowest: compounds 2, 3 and 1 (each within the scatter of the next).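

On an oxygen on an aromatic ring, 5,6-dimethylpyridin-2-yl in place of 6-chloropyridin-2-yl gives a 1.0-fold higher number from compound 2 to compound 3 (0.01 log units; within the scatter) in this assay. Among these compounds, this is the first change in one place that can be read, and at this position the read-out does not separate the two groups. Nothing measured here bears on the reason for this result.

Still open, going by these compounds, is whether a pyridin-2-yl carrying an amine or a nitrile on this oxygen would give a step beyond the scatter. Also open, on these data alone, is whether the same swap on the core of compound 1 would give a similar step.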